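Swapping an Ester for a Trifluoromethoxyphenyl: Expected Cytotoxicity

A few compounds are considered here, and "the series" means these few. Any claim that something is new, unique, unknown or untested is made for them only; others in the source may bear on it.

Three compounds sharing one core were measured in an ADME assay on PC-3 cells (Homo sapiens) for cytotoxicity, read by sulforhodamine B assay, with a stated time of 48 h, tested at 10 uM; a lower number here means less inhibition, a higher number more inhibition at the concentration tested (going by the name of the read-out). Compound 1 `CCCCc1cn(C(c2ccccc2)c2cc3cc(Br)ccc3nc2OC)nn1` gives 5.54%, compound 2 `COc1nc2ccc(Br)cc2cc1C(c1ccccc1)n1cc(-c2ccccc2F)nn1` gives 13.4%, and compound 3 `CCOC(=O)c1cn(C(c2ccccc2)c2cc3cc(Br)ccc3nc2OC)nn1` gives 16.1%. Compound 3 stands at the top of the three numbers; the nearest gap is a number 2.7 percentage points higher from compound 2 to compound 3 (within the scatter), within the scatter, and the furthest is a number 10.6 percentage points higher from compound 1 to compound 3 (beyond the scatter), beyond it. Compound 4 `COc1nc2ccc(Br)cc2cc1C(c1ccccc1)n1cc(-c2ccc(OC(F)(F)F)cc2)nn1` differs from compound 3 by 4-(trifluoromethoxy)phenyl in place of ethoxycarbonyl on an aromatic carbon. The step that bears on this is the one in which an aromatic group gave way to the ethoxycarbonyl, a number 2.7 percentage points higher from compound 2 to compound 3 (within the scatter); the other aromatic swap, a number 7.9 percentage points higher from compound 1 to compound 2 (within the scatter), also stayed within the scatter. Putting an aromatic group back in place of the ethoxycarbonyl is therefore expected to move the number little, a number 4.1 percentage points lower from compound 3 to compound 4 (within the scatter). Compound 4 is expected to give 12%, within 2% to 24%.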

Compound 4, a percentage reported as inhibition, at one concentration (the size of the read-out at that concentration, not a potency): 21.6%
Compound 4: the middle estimate sits 9.6 percentage points below what was measured, and the stated range covers the measured number.
By their numbers in this assay, from the lowest: compounds 1, 2, 3 and 4 (each within the scatter of the next, the first and the last beyond it).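

At this position on the five-membered aromatic ring, 4-(trifluoromethoxy)phenyl cannot be told apart from ethoxycarbonyl (a number 5.5 percentage points higher from compound 3 to compound 4 (within the scatter)) or from 2-fluorophenyl (a number 8.2 percentage points higher from compound 2 to compound 4 (within the scatter)). Against butyl it makes a modest difference (a number 16.1 percentage points higher from compound 1 to compound 4 (beyond the scatter)), so in this assay it joins ethoxycarbonyl as a second group that stands clear of butyl. No measurement is at hand to explain these differences.

From the compounds shown here alone, whether an amine or a carboxylic acid at this place would behave like these groups stays open. So does how a plain phenyl or a longer chain than butyl would compare.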